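This account rests on a few compounds, and the source may have more. Where it says the series, first, only, none or still open, it means among the compounds named here.

Working notes on the series. Three members have been run in a functional assay on HepG2 cells (Homo sapiens) for antiproliferative activity, read by MTT assay, with a stated time of 48 h; on this read-out higher numbers stand for weaker inhibition and lower numbers for stronger inhibition. Compound 1 `N#CC1=C(N)Oc2c(c3nc4ccccc4nc3c3ccccc23)C12C(=O)N(Cc1cnnn1-c1ccc(F)cc1)c1ccccc12` reports only a limit of the assay, > 50000 nM. Compound 2 `Cc1ccc(-n2nncc2CN2C(=O)C3(C(C#N)=C(N)Oc4c3c3nc5ccccc5nc3c3ccccc43)c3ccccc32)cc1C` likewise reports only a limit, > 50000 nM. Within the data shown here, compound 3 `CCc1ccccc1-n1nncc1CN1C(=O)C2(C(C#N)=C(N)Oc3c(N)cc4nc5ccccc5nc4c32)c2ccccc21` is the one member with a number: in this assay compound 3 gives 17900 nM. Among the measured compounds shown here, it therefore stands as the only measured value in the set. The other two results are summed up by the limit of > 50000 nM in this assay, at which 2 of the 3 values shown sit. For the measured compounds named here, the one paired step, a step that the two limits leave unreadable from compound 1 to compound 2, cannot be sized because both ends are limits.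

Compound 4 `CCc1cccc(CC)c1-n1nncc1CN1C(=O)C2(C(C#N)=C(N)Oc3c(N)cc4nc5ccccc5nc4c32)c2ccccc21` is not yet measured. It differs from compound 3 by ethyl in place of hydrogen on an aromatic carbon; cut one bond further out, the change reads 2-ethylphenyl to 2,6-diethylphenyl. Going by the values given here, no measured step touches this kind of change, and the only readable anchor is the value of compound 3. With nothing to point to a direction, the expectation for compound 4 is a step of a 1.0-fold higher number from compound 3 to compound 4 (0.00 log units; within the scatter), that is, no movement beyond the scatter. On that basis compound 4 is estimated at 18000 nM in this assay, within a range of 6000 nM to 50000 nM, with a real chance that the assay again returns only a limit.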

Compound 4, half-maximal inhibitory concentration: 16500 nM
Compound 4: middle estimate off by 1.1-fold (0.04 log units), on the high side; low and high end bracket the measured number.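

Among these compounds, the change from 2-ethylphenyl to 2,6-diethylphenyl gives the first step that can be read in this assay: a 1.1-fold lower number from compound 3 to compound 4 (0.04 log units; within the scatter). At this position, on an aromatic carbon ortho to a large group, adding an ethyl group therefore leaves the read-out within the scatter, whereas the earlier step on the same aryl substituent cannot be read, as both of its ends are limits. Compound 4 also joins compound 3 as a second member with a number, though the set as a whole still rests heavily on limits: the limit of > 50000 nM in this assay, at which 2 of the 4 values shown sit.

As far as these compounds go, whether the read-out stays within the scatter with other groups at this position remains open, for instance with an amine, a carboxylic acid, a methoxy group or a longer chain such as butyl. A single readable pair also cannot show whether the same change would behave alike on the core of compound 1, or whether the hydrogen and ethyl pair reflects a wider pattern across the series.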